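Same Halogen Swap Tried on a Second Core

The compounds below may be only part of what the source reports. "The series", "measured", "known", "first", "only" and "open" are said of these compounds alone.

Compound 1 `O=C1C(=O)N(CN2CCN(c3ccnc4cc(Cl)ccc34)CC2)c2cccc(Cl)c21` gives 25600 nM in an ADME assay on MCF-10A cells (Homo sapiens) for cytotoxicity, read by sulforhodamine B assay, with a stated time of 48 h; a lower number here means a stronger inhibitor of growth, a higher number a weaker inhibitor of growth. Compound 2 `O=C1C(=O)N(CN2CCN(c3ccnc4cc(Cl)ccc34)CC2)c2cccc(Br)c21` differs from compound 1 by bromo in place of chloro on an aromatic carbon and in this assay compound 2 gives 65600 nM, so that a 2.6-fold higher number from compound 1 to compound 2 (0.41 log units; beyond the scatter). Compound 3 `O=C1C(=O)N(CN2CCN(c3ccnc4cc(C(F)(F)F)ccc34)CC2)c2cc(Cl)ccc21` rests on another core; the difference between the two cores is not broken down here. In this assay compound 3 gives 32800 nM. Compound 4 `O=C1C(=O)N(CN2CCN(c3ccnc4cc(C(F)(F)F)ccc34)CC2)c2cc(Br)ccc21` has not yet been measured and differs from compound 3 by bromo in place of chloro on an aromatic carbon. The surroundings are not identical: in compound 1 the halogen sits ortho to a fused ring and meta to a fused ring, in compound 3 meta to a fused ring and para to a fused ring, so this is the same kind of change, not the same change. A step of similar size is expected for compound 4, namely a 2.4-fold higher number from compound 3 to compound 4 (0.39 log units; beyond the scatter), because a 2.6-fold higher number from compound 1 to compound 2 (0.41 log units; beyond the scatter). For compound 4 the expected value in this assay is 80000 nM, estimated to fall between 35000 nM and 180000 nM.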

Compound 4, concentration for 50% growth inhibition: 24500 nM
Compound 4: the middle estimate sits 3.3-fold (0.51 log units) above what was measured; the whole stated range lies above it.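

On the second core, bromo in place of chloro gives a 1.3-fold lower number from compound 3 to compound 4 (0.13 log units; within the scatter) in this assay, so the rise seen on the first core does not reappear. Set side by side, the two steps differ: the same change on two cores in this assay, a 2.6-fold higher number (0.41 log units; beyond the scatter) from compound 1 to compound 2 and a 1.3-fold lower number (0.13 log units; within the scatter) from compound 3 to compound 4, 3.4-fold (0.54 log units) apart, beyond the scatter of two such steps. In this series, then, the step measured on one core did not predict the step on the other, but two pairs cannot show which difference between the cores matters, or how the swap would behave on any further core.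

The compounds shown leave open what fluoro or an amine in the halogen's place would do on either core. They also leave open whether a third core would follow either step.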